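The source may report more compounds than this note shows. Statements on the series, on what has been measured and on what is new or still open speak of the compounds shown alone.

Compounds measured in an assay on isolated protein for inhibition of advanced glycosylation end product-specific receptor (Homo sapiens), read by FRET, with stated times of 30 min and 1 h, tested at 4 uM; on this read-out lower numbers stand for less inhibition and higher numbers for more inhibition at the one concentration tested (going by the name of the read-out):

compound 1, `CCN(CC)CCCOc1ccc(-c2nc3ccc(Oc4ccc(C(C)(C)C)cc4)cc3o2)cc1`, "not active" (no number reported)
compound 2, `CCN(CC)CCCOc1ccc(-c2nc3ccc(Oc4ccc(F)cc4)cc3o2)cc1`, 5.4%
compound 3, `Fc1ccc(Oc2ccc3nc(-c4ccc(OCCCN5CCCCC5)cc4)oc3c2)cc1`, 30.3%

Compound 2 stands lowest of the two numbers in this assay; compound 3 sits one step away, a number 24.9 percentage points higher from compound 2 to compound 3 (beyond the scatter), while compound 1 gives no number at all. Compound 4, `CCN(CC)CCCOc1ccc(-c2nc3ccc(Oc4ccc(C(F)(F)F)cc4)cc3o2)cc1`, is the compound not yet measured. It differs from compound 2 in one place: trifluoromethyl in place of fluoro on an aromatic carbon.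

Among the measured compounds shown here, no measured step bears directly on this change. For the measured compounds named here, the single measured step, from compound 2 to compound 3, concerns the amine at the end of the chain, not the group on the phenoxy ring, and so says nothing about the present change. What can be said is that compound 1, which carries tert-butyl at that same position, is reported as not active, and compound 2 itself is already low. The step is therefore expected to be none beyond the scatter, if anything slightly downward. Compound 4 is expected to give 4%, in the range -5% to 15%, which means an expected step of a number 1.4 percentage points lower from compound 2 to compound 4 (within the scatter).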

Compound 4, a percentage reported as inhibition, at one concentration (the size of the read-out at that concentration, not a potency): 34.9%
Compound 4: middle estimate off by 30.9 percentage points, on the low side, and the stated range ends below it.
By their numbers in this assay, from the lowest: compound 2; then compounds 3 and 4 (each within the scatter of the next).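

In this assay the group on the phenoxy ring proves able to move the read-out on its own, with the diethylamino chain and the shared core unchanged: the trifluoromethyl exchange gives a number 29.5 percentage points higher from compound 2 to compound 4 (beyond the scatter). Among the compounds shown here, the only earlier step lay at the amine, so this is the first sign that the place para to a large group also matters, and the outcome there depends on the group, since compound 1 with tert-butyl gives "not active" (no number reported) while compound 4 gives 34.9%. Nothing given here accounts for the effect of this exchange.

The compounds shown leave open how a chloro, methoxy or nitrile group would read at this same place. They also leave open whether trifluoromethyl and the piperidin-1-yl amine of compound 3 would add up when combined in one compound.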